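The source may report more compounds than this note shows. Statements on the series, on what has been measured and on what is new or still open speak of the compounds shown alone.

The three measured compounds:
compound 1, `CCCCCCCCCCc1ccc(-c2noc(C(Cl)CCN)n2)cc1`, gives 5% in an assay on HeLa cells for inhibition of sphingosine-1-phosphate transporter SPNS2 (Mus musculus), read by LC-MS, tested at 2 uM; on this read-out higher numbers stand for more inhibition at the one concentration tested (going by the name of the read-out) and lower numbers for less inhibition;
compound 2, `CCCCCCCCCCc1ccc(-c2noc([C@@H](N)CCCCN)n2)cc1`, gives 43% in this assay;
compound 3, `CCCCCCCCCCc1ccc(-c2noc(CCCN3CCCCC3)n2)cc1`, gives 0% in this assay.

Compound 3 holds the lowest of the three numbers, but the gap to compound 1 is small: a number 5 percentage points lower from compound 1 to compound 3 (within the scatter), so the two cannot be told apart. The gap to compound 2 is clear, since a number 43 percentage points lower from compound 2 to compound 3 (beyond the scatter), and this is the only step shown that changes the number by more than the scatter. Compound 4, `CCCCCCCCCCc1ccc(-c2noc(CC(O)CN3CCCCC3)n2)cc1`, is the next compound. It differs from compound 3 by hydroxy in place of hydrogen on a saturated chain carbon bound to two saturated chain carbons.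

Within the data shown here, none of the measured steps adds such a group: the steps from compound 1 to compound 2 and from compound 1 to compound 3 replace the whole chain on the aromatic carbon, and the step from compound 2 to compound 3 swaps one chain for another. Nothing shown therefore speaks for a gain or a loss on adding a hydroxy, and the expected step in this assay is none beyond the scatter. On that basis compound 4 is expected to give 3%, within a range of -8% to 15%, which means an estimated step of a number 3 percentage points higher from compound 3 to compound 4 (within the scatter).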

Compound 4, a percentage reported as inhibition, at one concentration (the size of the read-out at that concentration, not a potency): 2%
Estimate against measurement, compound 4: 1 percentage points above; measured number inside the range.
By their numbers in this assay, from the lowest: compounds 3, 4 and 1 (each within the scatter of the next); then compound 2.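

In this assay, hydroxy in place of hydrogen on a saturated chain carbon bound to two saturated chain carbons gives a number 2 percentage points higher from compound 3 to compound 4 (within the scatter) and so has no readable effect here, although compound 3, at 0% in this assay, leaves room to show a gain but hardly a loss. The new 2-hydroxy-3-(piperidin-1-yl)propyl chain stays clearly apart from the 1,5-diaminopentyl chain, with a number 41 percentage points lower from compound 2 to compound 4 (beyond the scatter) and a large step, yet cannot be told apart from the chlorine-bearing chain, with a number 3 percentage points lower from compound 1 to compound 4 (within the scatter) inside the scatter. No independent measurement is available to explain any of these numbers.

The compounds shown leave open whether an amine or a carboxylic acid in place of the hydroxy on this chain would lift the number beyond the scatter. They also leave open whether the hydroxy would make any difference on a chain that starts from a higher number, such as the 1,5-diaminopentyl chain, or whether a primary amine in place of the piperidine ring would do so.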